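The source may hold more compounds than are shown below. What is called first, only, known or untested is meant among the compounds shown, and "the series" means these compounds.

- Compound 1 `CC1=CC(=O)C(N(C)C)=CC1=O`: 6200 nM
- Compound 2 `CC1=CC(=O)C(C(C)(C)C)=CC1=O`: 7500 nM
- Compound 3 `CC1=C(Cl)C(=O)C(C(C)(C)C)=C(Cl)C1=O`: 4500 nM

All three compounds were read in a functional assay on A2780 cells (Homo sapiens) for inhibition, read by sulforhodamine B assay, with a stated time of 72 h; a higher number here means a weaker inhibitor, a lower number a stronger inhibitor. Compound 2, at 7500 nM, lies within the scatter of both compound 1 and compound 3. Compound 4 `CC(C)(C)C1=CC(=O)C=CC1=O` differs from compound 2 as follows: hydrogen in place of methyl on a double-bonded ring carbon. This exact change has not been measured. For the measured compounds named here, the only measured single-place step, a 1.2-fold higher number from compound 1 to compound 2 (0.08 log units; within the scatter), involves tert-butyl in place of dimethylamino at another place and stays within the scatter. No shift beyond the scatter is therefore expected in this assay. The expected change is a 1.3-fold lower number from compound 2 to compound 4 (0.10 log units; within the scatter). Compound 4 is estimated at 6000 nM, within an expected range of 2500 nM to 14000 nM.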

Compound 4, half-maximal inhibitory concentration: 5700 nM
For compound 4 the middle estimate is 1.1-fold (0.02 log units) above the measured one; measured number inside the range.
By their numbers in this assay, from the lowest: compounds 3, 4, 1 and 2 (each within the scatter of the next).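

In this assay, the methyl on a double-bonded ring carbon, three ring bonds from the ring atom that bears a tert-butyl group, gives way to hydrogen with a 1.3-fold lower number from compound 2 to compound 4 (0.12 log units; within the scatter). For the compounds shown here, the earlier step concerned only tert-butyl in place of dimethylamino at another place, so this is the first reading at this position, and here the methyl is not needed to hold the number within the scatter. Nothing available explains this result.

Only methyl and hydrogen are compared at this ring carbon. On these data alone, whether an amine, a carboxylic acid or a longer chain there would also stay within the scatter remains open.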